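The source may hold more compounds than are shown below. What is called first, only, known or untested is meant among the compounds shown, and "the series" means these compounds.

- compound 1 `CC(=O)c1cc(-c2ccc(S(N)(=O)=O)cc2)n(-c2ccc(Cl)cc2)n1` 86800 nM
- compound 2 `NS(=O)(=O)c1ccc(-c2cc(C(=O)C3CCC3)nn2-c2ccc(Cl)cc2)cc1` 17200 nM

Among the measured compounds shown here, in a physicochemical assay for solubility, read by HPLC, in phosphate buffer, measured as kinetic solubility, at pH 7.4 (on this read-out higher numbers stand for higher solubility and lower numbers for lower solubility), compound 2 gives 17200 nM and stands lowest of the two numbers so far. The change to compound 3 `NS(=O)(=O)c1ccc(-c2cc(C(=O)N3CCCCC3)nn2-c2ccc(Cl)cc2)cc1` is piperidin-1-yl in place of cyclobutyl on a carbonyl carbon and reads as piperidin-1-yl in place of cyclobutyl on a carbonyl carbon. For the measured compounds named here, the only measured step bearing on it is the modest 5.0-fold lower number from compound 1 to compound 2 (0.70 log units; beyond the scatter) for cyclobutyl in place of methyl on a carbonyl carbon. A smaller fall is expected in this assay with an estimated 1.4-fold lower number from compound 2 to compound 3 (0.16 log units; within the scatter) that may stay within the scatter. Compound 3 is estimated at 12000 nM with an expected range of 4000 nM to 35000 nM in this read-out.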

Compound 3, solubility: 65900 nM
Estimate against measurement, compound 3: 5.5-fold (0.74 log units) below; measured number outside the range, above it.
By their numbers in this assay, from the lowest: compound 2; then compounds 3 and 1 (each within the scatter of the next).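

On the carbonyl carbon, the larger ring does not simply continue the earlier fall: in this assay piperidin-1-yl in place of cyclobutyl gives a 3.8-fold higher number from compound 2 to compound 3 (0.58 log units; beyond the scatter) and reverses most of the first step. The change a 1.3-fold lower number from compound 1 to compound 3 (0.12 log units; within the scatter) lies within the scatter, so piperidin-1-yl and methyl at this place cannot be told apart on this read-out. No measurement shown here accounts for the reversal.

The compounds shown leave open whether a morpholin-4-yl ring or a dimethylamino group on the same carbonyl carbon would read like compound 3. They also leave open how a cyclohexyl ketone, the all-carbon counterpart of compound 3, would read.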